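This account rests on a few compounds, and the source may have more. Where it says the series, first, only, none or still open, it means among the compounds named here.

Compound 3 `Brc1cccc2c1nnn2CC1CC1` stands at the bottom of the three numbers recorded so far in an ADME assay on microsomes from liver (Rattus norvegicus, strain Wistar) for metabolic stability, tested at 2.5 uM; a higher number here means faster removal of the compound, a lower number slower removal. Compound 3 gives 0.6 mL/min/g, whereas compound 2 `Brc1cccc2c1nnn2CC1CCC1` gives 12 mL/min/g and compound 1 `Brc1cccc2c1nnn2CC1CCCC1` gives 14.6 mL/min/g. The steps among these three are uneven: a 1.2-fold lower number from compound 1 to compound 2 (0.09 log units; within the scatter), whereas a 24-fold lower number from compound 1 to compound 3 (1.39 log units; beyond the scatter) and a 20-fold lower number from compound 2 to compound 3 (1.30 log units; beyond the scatter). Going by the values given here, the one compound carrying the three-membered ring thus sits far apart from the other two.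

Compound 4 `CC(C)Cn1nnc2c(Br)cccc21` has not yet been run in this assay. The change from compound 3 to compound 4 is isopropyl in place of cyclopropyl on a saturated chain carbon bound to an aromatic nitrogen. Among the compounds with values here, the measured steps that bear on it are the two large ones into compound 3, both of which concern the ring on that saturated chain carbon; no measured step replaces a ring by an open chain of the same size. The ring shrinkage from compound 1 or compound 2 to compound 3 gave large drops, so opening the three-membered ring to an isopropyl is expected to move the number back upward, though by less than the full span to compound 2. Compound 4 is therefore expected to give 3 mL/min/g, with a range from 0.8 mL/min/g to 12 mL/min/g, which means an expected step of a 5.0-fold higher number from compound 3 to compound 4 (0.70 log units; beyond the scatter).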

Compound 4, intrinsic clearance in a liver preparation (reported as CLH), per the amount of preparation that the assay uses: 4 mL/min/g
Estimate against measurement, compound 4: 1.3-fold (0.12 log units) below; the measured number falls inside the stated range.
By their numbers in this assay, from the lowest: compound 3; then compound 4; then compounds 2 and 1 (each within the scatter of the next).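

In this assay, putting the open isopropyl in place of the cyclopropyl on a saturated chain carbon bound to an aromatic nitrogen gives a 6.7-fold higher number from compound 3 to compound 4 (0.82 log units; beyond the scatter), although the two groups have the same count of heavy atoms. The earlier steps shown here changed only ring size, whereas this one shows that removing the ring while keeping that count also moves the number beyond the scatter. The open group does not reach the larger rings, however, with a 3.0-fold lower number from compound 2 to compound 4 (0.48 log units; beyond the scatter) and a 3.7-fold lower number from compound 1 to compound 4 (0.56 log units; beyond the scatter), so these four compounds now fall on three levels, with the isopropyl compound in the middle. No accompanying measurement accounts for these differences.

The compounds shown leave open whether a longer chain, such as n-butyl, or a more branched group, such as tert-butyl, would give a number nearer to the larger rings or nearer to the cyclopropyl. As far as these compounds go, the bromine of the shared core is also the same throughout, so it remains open whether these steps would hold with a chlorine or a nitrile in its place.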